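This account rests on a few compounds, and the source may have more. Where it says the series, first, only, none or still open, it means among the compounds named here.

Within the data shown here, in an ADME assay on S9 fraction from liver (Rattus norvegicus) for metabolic stability, read by LC-MS, using NADPH, with a stated time of 60 min, tested at 10 uM (a higher number here means that more of the compound is left, a lower number that less of the compound is left), compound 1 `N#CC1(c2cc(CC(O)C3CC3)cc(-c3ccnc4[nH]nc(C(F)(F)F)c34)c2)CC1` gives 0% and compound 2 `N#CC1(c2cc(CCF)cc(-c3ccnc4[nH]nc(C(F)(F)F)c34)c2)CC1` gives 67% as the higher of the two numbers so far. Compound 3 `CCc1cc(-c2ccnc3[nH]nc(C(F)(F)F)c23)cc(C2(C#N)CC2)c1` differs from compound 2 in one place: hydrogen in place of fluoro on a saturated chain carbon, two bonds along the chain from an aromatic carbon with hydrogen in place of fluoro on a saturated chain carbon, two bonds along the chain from an aromatic carbon. Among the measured compounds shown here, the one measured step of a number 67 percentage points higher from compound 1 to compound 2 (beyond the scatter) is large and touches this same chain, but it exchanged cyclopropyl(hydroxy)methyl and not fluoro, so it sets no firm size here. A moderate drop is expected, read as a number 17 percentage points lower from compound 2 to compound 3 (beyond the scatter) in this estimate. In this assay the estimated value for compound 3 is 50% with 25% to 75% as its expected range.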

Compound 3, percent of the compound remaining: 78%
Compound 3: the middle estimate sits 28 percentage points below what was measured, outside the stated range (above it).
By their numbers in this assay, from the lowest: compound 1; then compound 2; then compound 3.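

In this assay, going from 2-fluoroethyl to ethyl gives a number 11 percentage points higher from compound 2 to compound 3 (beyond the scatter) and so the fluoro on this saturated chain carbon is not needed to keep the number high. Methyl in place of cyclopropyl(hydroxy)methyl on the saturated chain carbon bound to an aromatic carbon gives a number 78 percentage points higher from compound 1 to compound 3 (beyond the scatter) as a second reading of the same chain. No available evidence explains either step.

Still open, on these data alone, is whether an amine, a carboxylic acid or a longer chain such as propyl at this position would keep the number this high. Also open, as far as these compounds go, is whether the hydroxy or the cyclopropyl part of compound 1 goes with its low number.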